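This account rests on a few compounds, and the source may have more. Where it says the series, first, only, none or still open, it means among the compounds named here.

In a functional assay on MDA-MB-231 cells (Homo sapiens) for antiproliferative activity, read by XTT assay, with a stated time of 72 h (on this read-out higher numbers stand for weaker inhibition and lower numbers for stronger inhibition), compound 1 `COc1ccc(-c2cc3ccccc3nc2C=O)cc1` gives only a limit of > 10000 nM. Compound 2 `COc1ccc(C(=O)/C=C/c2nc3ccccc3cc2-c2ccc(OC)cc2)cc1`, which carries a longer unsaturated ketone chain from the shared core, gives 7540 nM. Compound 3 `COc1ccc(-c2cc3ccccc3nc2/C=C/C(=O)c2ccc(OC)cc2OC)cc1` gives 3210 nM, the lowest of the two numbers shown. The single-change step measured so far is a 2.3-fold lower number from compound 2 to compound 3 (0.37 log units; beyond the scatter). Compound 4 `COc1ccc(-c2cc3ccccc3nc2/C=C/C(=O)c2ccco2)cc1` differs from compound 3 by furan-2-yl in place of 2,4-dimethoxyphenyl on a carbonyl carbon. That measured step added a methoxy to the very 2,4-dimethoxyphenyl that now leaves, and since the earlier step was modest, removing both methoxy groups with the ring is expected to push the number up by roughly a 2.0-fold higher number from compound 3 to compound 4 (0.31 log units; beyond the scatter). Compound 4 is therefore estimated at 6500 nM, with a likely range from 1800 nM to 20000 nM.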

Compound 4, half-maximal inhibitory concentration: 630 nM
Compound 4: middle estimate off by 10-fold (1.01 log units), on the high side; measured number below the stated range.
By their numbers in this assay, from the lowest: compound 4; then compound 3; then compound 2. At a limit, above all of these: compound 1.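

In this assay, the ring on the carbonyl carbon turns out to matter more than its methoxy groups: furan-2-yl, with fewer heavy atoms than either phenyl ring it replaces, gives a 5.1-fold lower number from compound 3 to compound 4 (0.71 log units; beyond the scatter) and a 12-fold lower number from compound 2 to compound 4 (1.08 log units; beyond the scatter), both larger than the earlier methoxy step, a 2.3-fold lower number from compound 2 to compound 3 (0.37 log units; beyond the scatter). Extending formyl to the 2-((furan-2-yl)carbonyl)ethenyl chain gives an at least 15-fold lower number from compound 1 to compound 4 (1.20 log units; beyond the scatter), a step that starts from a limit: the limit of > 10000 nM in this assay, at which 1 of the 4 values shown sits.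

On these data alone, what stays open is whether this drop needs furan-2-yl itself or only the absence of a methoxyphenyl ring. A thiophen-2-yl or an unsubstituted phenyl on that carbonyl carbon would help separate the two.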